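The compounds below may be only part of what the source reports. "The series", "measured", "known", "first", "only" and "open" are said of these compounds alone.

Measured so far in a physicochemical assay for solubility, in phosphate buffer, measured as kinetic solubility, with a stated time of 1 h, at pH 7.4; on this read-out higher numbers stand for higher solubility and lower numbers for lower solubility:
Compound 1 `CC(C)(c1cc([C@@]23CCOC[C@@H]2C3)nc(-c2ccc(NC(=S)NCCO)cc2)n1)S(C)(=O)=O` gives 145 ug/mL
Compound 2 `CCNC(=O)Nc1ccc(-c2nc(C(C)(C)S(C)(=O)=O)cc([C@@]34CCOC[C@@H]3C4)n2)cc1` gives 78 ug/mL
Compound 3 `CNCC(=O)Nc1ccc(-c2nc(C(C)(C)S(C)(=O)=O)cc([C@@]34CCOC[C@@H]3C4)n2)cc1` gives 257 ug/mL

Compound 1 cannot be told apart from either of the others, since a 1.9-fold lower number from compound 1 to compound 2 (0.27 log units; within the scatter) and a 1.8-fold higher number from compound 1 to compound 3 (0.25 log units; within the scatter) both stay within the scatter. Only a 3.3-fold higher number from compound 2 to compound 3 (0.52 log units; beyond the scatter) goes beyond it, and that step is modest.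

The next compound is compound 4 `CC(C)(c1cc([C@]23CCOC[C@H]2C3)nc(-c2ccc(NC(=S)NCCO)cc2)n1)S(C)(=O)=O`, and the change is this: the two compounds have the same atoms and bonds and differ only in configuration as drawn: 2 of 2 stereo elements differ (all stereocentres are inverted: mirror images); a stereocentre at a saturated ring carbon is drawn S in compound 1 and R in compound 4; a stereocentre at a saturated ring carbon is drawn R in compound 1 and S in compound 4. All stereocentres are inverted, so the two are mirror images. For the measured compounds named here, none of the measured steps inverts a stereocentre. They change only the chain, and compound 4 keeps the chain of compound 1, so they give no measure of this change. No step beyond the scatter is therefore expected in this assay, and no direction is favoured. The estimated step is no change at the digits printed from compound 1 to compound 4 (within the scatter). Going by the values given here, this expectation rests on compound 1 at 145 ug/mL, the only compound with this chain that has a value so far. Compound 4 is estimated at 145 ug/mL with a range of 80 ug/mL to 260 ug/mL as expected.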

Compound 4, solubility: 173 ug/mL
Beside the measured number, compound 4's estimate is 1.2-fold (0.08 log units) below it, within the range that was stated.
By their numbers in this assay, from the lowest: compounds 2, 1, 4 and 3 (each within the scatter of the next, the first and the last beyond it).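

In this assay, for the compounds shown here, the first step to test configuration rather than the chain gives a 1.2-fold higher number from compound 1 to compound 4 (0.08 log units; within the scatter). Going by these compounds alone, the two compounds therefore cannot be told apart on this read-out, and this is the first measure of what inverting both stereocentres at the saturated ring carbons does with the chain of compound 1 held constant. This pair isolates that inversion, with no other structural change to confound the reading: the fact that compounds 1 and 4 differ only in the configuration as drawn.

The compounds shown leave open whether mirror images would stay as close with the urea chain of compound 2 or the (methylamino)methyl chain of compound 3, since this single pair speaks only for the chain of compound 1. They also leave open how a carboxylic acid or a longer chain on the nitrogen on an aromatic ring would read in this assay.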